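Adding Fluoro to the Unsubstituted Phenyl of Compound 3

A few compounds are considered here, and "the series" means these few. Any claim that something is new, unique, unknown or untested is made for them only; others in the source may bear on it.

Measured compounds:
compound 1 `COc1ccccc1NC(=O)SC[C@H](NC(C)=O)C(=O)O` gives > 200000 nM in a functional assay on UACC-62 cells (Homo sapiens) for cytotoxicity, read by MTT assay, with a stated time of 6 days; on this read-out higher numbers stand for weaker inhibition and lower numbers for stronger inhibition
compound 2 `CC(=O)N[C@@H](CSC(=O)Nc1ccc(F)cc1)C(=O)O` gives 36 nM in this assay
compound 3 `CC(=O)N[C@@H](CSC(=O)Nc1ccccc1)C(=O)O` gives 125000 nM in this assay

Compound 1 sits at a limit, (the limit of > 200000 nM in this assay, at which 1 of the 3 values shown sits), so it contributes no number. Among the two numbers shown, compound 3 has the highest, and its only numbered neighbour is compound 2, which lies far lower. The step from compound 2 to compound 3 is a 3500-fold higher number from compound 2 to compound 3 (3.54 log units; beyond the scatter), a large change tied to hydrogen in place of fluoro on an aromatic carbon. The step from compound 1 to compound 3 is an at least 1.6-fold lower number from compound 1 to compound 3 (0.20 log units; that floor lies within the scatter), resting on a limit and not telling much.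

Compound 4 `CC(=O)N[C@@H](CSC(=O)Nc1ccccc1F)C(=O)O` differs from compound 3 by fluoro in place of hydrogen on an aromatic carbon, placed ortho to a large group, whereas the fluoro of compound 2 sits on another aromatic carbon. Among the measured compounds shown here, the one measured step that bears on this change, the step from compound 2 to compound 3, was large and downward in number when fluoro was removed, so a lower number for compound 4 is expected, though a fluoro in a different place may not repeat that size. Compound 4 is estimated at 10000 nM, with a range from 300 nM to 150000 nM, implying an expected step of a 13-fold lower number from compound 3 to compound 4 (1.10 log units; beyond the scatter).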

Compound 4, half-maximal inhibitory concentration: > 200000 nM
Compound 4 was reported as a limit (the forecaster's own chance of this, stated with the estimate: 5%); at least 20-fold (1.30 log units) between middle value and limit.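

In this assay compound 4 gives > 200000 nM, which is a limit and not a number, and it is not alone there: the limit of > 200000 nM in this assay, at which 2 of the 4 values shown sit. Fluoro in place of hydrogen, ortho to a large group, gives an at least 1.6-fold higher number from compound 3 to compound 4 (0.20 log units; that floor lies within the scatter), so this place shows no trace of the low number of compound 2, which gives 36 nM on another aromatic carbon of the ring. Among the compounds shown, adding fluoro therefore does not by itself bring the number down, and compound 2 is the only one that goes against the high numbers of the set; the step from compound 1 to compound 4 cannot be read, as both its ends are limits.

Going by these compounds, it stays open whether a chloro, a methyl or an amine at this same place would also stay at the limit. Also open, on these data alone, is whether the low number of compound 2 belongs to fluoro in particular, or whether a chloro or a hydroxyl on that other aromatic carbon would give a similar number.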